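Pyrazole-thiazole acids on BJAB cells: a pyridyl swap

This account rests on a few compounds, and the source may have more. Where it says the series, first, only, none or still open, it means among the compounds named here.

Measured so far:
compound 1 `Cc1c(-c2cc(Cl)cc(Cl)c2)c(C(=O)O)nn1-c1nc(-c2ccncc2)c(SC(C)C)s1`, "not active" (no number reported) in a functional assay on BJAB cells (Homo sapiens) for antiproliferative activity, with a stated time of 4 days; a lower number here means that less compound is needed, a higher number that more compound is needed for the effect
compound 2 `Cc1cc(C#N)cc(-c2c(C)nn(-c3nc(-c4ccc(Cl)c(Cl)c4)c(SC(C)C)s3)c2C(=O)O)c1`, 4800 nM
compound 3 `Cc1c(-c2cc(Cl)cc(Cl)c2)c(C(=O)O)nn1-c1nc(-c2cc(Cl)cc(Cl)c2)c(SC(C)C)s1`, 2000 nM

Three compounds of the shared core carry numbers or a verdict in this assay. Compound 1, which bears pyridin-4-yl on the thiazole side, is reported as "not active" (no number reported) with no number. Of the two compounds with a number, compound 2 gives 4800 nM and compound 3 gives 2000 nM; compound 2 therefore stands at the higher of the two numbers, and its gap to compound 3 lies beyond the scatter of repeated measurements.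

Compound 4 `Cc1nn(-c2nc(-c3ccc(Cl)c(Cl)c3)c(SC(C)C)s2)c(C(=O)O)c1-c1ccncc1` is not yet measured. It differs from compound 2 in one place: pyridin-4-yl in place of 3-cyano-5-methylphenyl on an aromatic carbon. Among the measured compounds shown here, no step between measured compounds touches this position, so the size of the step can only be expected, not read off. For the measured compounds named here, the one precedent for a pyridin-4-yl group, compound 1, is reported as "not active" (no number reported), though that group sits on the other ring there. On this basis the number for compound 4 is expected to move upward from that of compound 2, by a step of roughly a 1.9-fold higher number from compound 2 to compound 4 (0.27 log units; within the scatter), with a real chance that only a limit is reported. The estimate for compound 4 is 9000 nM, within 2500 nM to 30000 nM.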

Compound 4, half-maximal effective concentration: 5900 nM
Compound 4: middle estimate off by 1.5-fold (0.18 log units), on the high side; low and high end bracket the measured number.
By their numbers in this assay, from the lowest: compound 3; then compounds 2 and 4 (each within the scatter of the next).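

The position on the aromatic carbon next to the ring atom that bears a carboxy group accepts a real change of substituent in this assay: pyridin-4-yl in place of 3-cyano-5-methylphenyl gives a 1.2-fold higher number from compound 2 to compound 4 (0.09 log units; within the scatter). Among the compounds shown here, this pair is the first direct reading at this position, and it shows that the nitrile and the methyl group on the leaving ring can go, and a ring nitrogen can enter, without a difference that can be told from the scatter of repeated measurements. Nothing available bears on why these two substituents give numbers this close, so the result stands as an observation only.

The compounds shown leave open whether the nitrile or the methyl group matters alone, since both leave together in this one step, and how a plain phenyl, a pyridin-3-yl or a saturated ring such as piperidine would read at this position. They also leave open what an amine or a second carboxylic acid on this ring would do, and whether this tolerance holds when the dichlorophenyl group on the other ring of the shared core is exchanged.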